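A few compounds are considered here, and "the series" means these few. Any claim that something is new, unique, unknown or untested is made for them only; others in the source may bear on it.

Measured so far in a functional assay on SW480 cells (Homo sapiens) for cytotoxicity, read by MTT assay, with a stated time of 24 h; on this read-out lower numbers stand for stronger inhibition and higher numbers for weaker inhibition:

compound 1 `C=CC1=C(C(=O)Nc2ccc(C)cc2)C(c2ccc(F)cc2)OC1`, a limit of the assay: > 100000 nM
compound 2 `C=CC1=C(C(=O)Nc2ccc(C)cc2)C(c2ccc(OC)cc2)OC1`, a limit of the assay: > 100000 nM
compound 3 `C=CC1=C(C(=O)O)C(c2ccc(OC)cc2)OC1`, a limit of the assay: > 100000 nM

All three values sit at the limit of > 100000 nM in this assay, at which 3 of the 3 values shown sit. Compound 2 therefore stands where the other two stand, at a limit rather than at a number. The step that the two limits leave unreadable from compound 1 to compound 2 and the step that the two limits leave unreadable from compound 2 to compound 3 are both unreadable for that reason. Compound 4 `C=CC1=C(C(=O)NCc2ccccc2F)C(c2ccc(OC)cc2)OC1` differs from compound 2 by 2-fluorobenzyl in place of 4-methylphenyl on an amide-type nitrogen. Among the measured compounds shown here, no measured step reads out a size that could guide this change, so no shift beyond the scatter can be expected from it. Compound 4 is therefore expected to give 150000 nM, within 40000 nM to 600000 nM, most likely again as a limit. The expected step is a step that the limit leaves unreadable from compound 2 to compound 4.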

Compound 4, half-maximal inhibitory concentration: > 100000 nM
Compound 4 ended at the assay's limit; the forecaster's own chance of this, stated with the estimate: 80%; the middle value does not contradict the limit.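

Compound 2 and compound 4 both end at a limit rather than a number, so the step between them cannot be read: the limit of > 100000 nM in this assay, at which 4 of the 4 values shown sit. The compounds shown leave open which structural change, if any, would give a measurable value.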